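The compounds below may be only part of what the source reports. "The series", "measured", "known", "first", "only" and "open" are said of these compounds alone.

Within the data shown here, the three compounds measured so far share one core, and differ only in the aromatic ring hanging from a double-bonded chain carbon. Compound 1 `C=CCn1c(=O)/c(=C\c2ccc(F)c(Br)c2)[nH]c(=O)/c1=C\c1ccccc1OC` carries a bromine and a fluorine on that ring and is recorded as "not active" (no number reported) in a functional assay on Huh-7 cells (Homo sapiens) for cytotoxicity, read by CCK-8 assay, with a stated time of 72 h (a higher number here means a weaker inhibitor, a lower number a stronger inhibitor), with no number given. Compound 2 `C=CCn1c(=O)/c(=C\c2cccc(Cl)c2)[nH]c(=O)/c1=C\c1ccccc1OC` carries a single chlorine and in this assay gives 8900 nM. Compound 3 `C=CCn1c(=O)/c(=C\c2ccc(C)cc2)[nH]c(=O)/c1=C\c1ccccc1OC` carries a methyl group instead and is recorded in this assay as "not active" (no number reported) without a number, like compound 1, so compound 3 stands among the two compounds for which no figure exists at all, with only compound 2 providing a measured value.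

Compound 4 `C=CCn1c(=O)/c(=C\c2ccc(Cl)c(Cl)c2)[nH]c(=O)/c1=C\c1ccccc1OC` is the next step from compound 3: 3,4-dichlorophenyl in place of 4-methylphenyl on a double-bonded chain carbon bound to an aromatic carbon. Among the measured compounds shown here, no measured step links these two, and with compound 3 lacking a number, no size of change can be drawn from the data. The expectation is that compound 4 will give a measurable but weak value, since compound 2 with its single chlorine reached 8900 nM. Compound 4 is therefore estimated at 10000 nM, with a range from 3000 nM to 40000 nM.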

Compound 4, half-maximal inhibitory concentration: "not active" (no number reported)
The entry for compound 4 holds no number, so the estimate cannot be set against anything.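

Compound 3 and compound 4 are both recorded in this assay as "not active" with no number, so no step can be read between them. No evidence bears on this result. The compounds shown leave open what separates compound 2, the only one with a number, from the other three.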